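This account rests on a few compounds, and the source may have more. Where it says the series, first, only, none or still open, it means among the compounds named here.

Measured compounds:
Compound 1, `COc1ccc(Br)cc1C(=O)Nc1ccc(Sc2nc3ccccc3s2)cc1`, in an ADME assay on HEK293 cells (Homo sapiens) for cytotoxicity, read by reporter gene assay and resazurin assay, with a stated time of 48 h (on this read-out higher numbers stand for lower toxicity in this test and lower numbers for higher toxicity in this test), gives > 100000 nM, a limit of the assay rather than a number.
Compound 2, `COc1c(Br)cc(Br)cc1C(=O)Nc1ccc(Sc2nc3ccccc3s2)cc1`, in this assay gives > 100000 nM, likewise a limit of the assay.

Among the measured compounds shown here, compound 1 therefore stands only at a limit in this assay, and the one other value shown beside it is also a limit. For the measured compounds named here, the only measured step, a step that the two limits leave unreadable from compound 1 to compound 2, adds a bromo in place of hydrogen on an aromatic carbon, and its size cannot be read. The whole of the evidence is the limit of > 100000 nM in this assay, at which 2 of the 2 values shown sit, so no step in either direction has yet been seen in this assay.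

Compound 3, `O=C(Nc1ccc(Sc2nc3ccccc3s2)cc1)c1cccc(Br)c1O`, has not been measured. It differs from compound 1 in one place: 3-bromo-2-hydroxyphenyl in place of 5-bromo-2-methoxyphenyl on a carbonyl carbon. Going by the values given here, no measured step bears directly on this change, and the one step that exists is unreadable, so there is no basis for expecting a step beyond the scatter in this assay in either direction.

Compound 3 is therefore expected to sit near 100000 nM, within a range of 30000 nM to 300000 nM. The step this expectation implies is a number no higher from compound 1 to compound 3 (the limit leaves the size open), and it is most likely that the assay will again report only a limit.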

Compound 3, half-maximal cytotoxic concentration: 71000 nM
The estimate for compound 3 lay 1.4-fold (0.15 log units) above the measured number, within the range that was stated.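

Compound 3 gives this series its first true number in this assay, 71000 nM, so a change at this place on the carbonyl carbon can bring the read-out inside the range the assay can measure. Going by these compounds, the step is an at least 1.4-fold lower number from compound 1 to compound 3 (0.14 log units; that floor lies within the scatter), and the value of compound 1 is only a limit, so the true size stays open and the floor alone does not show a real difference in toxicity. The change also does two things at once, since 3-bromo-2-hydroxyphenyl has 1 hydrogen-bond donor where 5-bromo-2-methoxyphenyl has 0 and the bromo carries a different number in its name, while most of the picture still rests on limits: the limit of > 100000 nM in this assay, at which 2 of the 3 values shown sit.

The compounds shown do not separate the swap of methoxy for hydroxy from the shift of the bromo, so which of the two goes with the measurable number remains open. Also open, on these data alone, is what an amine or a carboxylic acid on this ring would give, and whether any such change would move the read-out beyond the usual scatter.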